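The source may hold more compounds than are shown below. What is called first, only, known or untested is meant among the compounds shown, and "the series" means these compounds.

Measured in a functional assay on KB cells (Homo sapiens) for antiproliferative activity, read by sulforhodamine B assay, with a stated time of 3 days; a higher number here means that more compound is needed for the effect, a lower number that less compound is needed:
- compound 1 `CCC1=C(O)c2c(oc(-c3ccc(CC(C)C)cc3)cc2=O)C(CC)(CC)C1=O`: 29.3 uM
- compound 2 `CCC1=C(O)c2c(oc(-c3ccc(C(F)(F)F)cc3)cc2=O)C(CC)(CC)C1=O`: 35.7 uM
- compound 3 `CCC1=C(O)c2c(oc(-c3ccc(OC(F)(F)F)cc3)cc2=O)C(CC)(CC)C1=O`: 36.5 uM

Compound 3 , at 36.5 uM, lies within the scatter of both compound 1 and compound 2 . Compound 4 `CCC1=C(O)c2c(oc(-c3ccc(COC)cc3)cc2=O)C(CC)(CC)C1=O` carries methoxymethyl in place of trifluoromethoxy on an aromatic carbon. Three measured steps exchange the group at this same place: a 1.2-fold higher number from compound 1 to compound 2 (0.09 log units; within the scatter), a 1.2-fold higher number from compound 1 to compound 3 (0.10 log units; within the scatter) and a 1.0-fold higher number from compound 2 to compound 3 (0.01 log units; within the scatter). Each stays within the scatter, although none of them involves methoxymethyl, so they bear on this change only indirectly. In this assay, no shift beyond the scatter is therefore expected. The expected step is a 1.1-fold lower number from compound 3 to compound 4 (0.06 log units; within the scatter). For compound 4 the estimated value is 32 uM, with an expected range of 18 uM to 55 uM.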

Compound 4, concentration for half-maximal effect: > 52.4 uM
Compound 4: no number, only a limit (the forecaster's own chance of this, stated with the estimate: 10%); middle value at least 1.6-fold (0.21 log units) away from the limit.
By their numbers in this assay, from the lowest: compounds 1, 2 and 3 (each within the scatter of the next). At a limit, above all of these: compound 4.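

In this assay compound 4 gives no number, only a limit: the limit of > 52.4 uM in this assay, at which 1 of the 4 values shown sits. Among these compounds, this is the first group at this position, on an aromatic carbon para to a large group, to end at a limit rather than a number. The steps are an at least 1.4-fold higher number from compound 3 to compound 4 (0.15 log units; that floor lies within the scatter), an at least 1.4-fold higher number from compound 2 to compound 4 (0.16 log units; that floor lies within the scatter) and an at least 1.7-fold higher number from compound 1 to compound 4 (0.25 log units; that floor lies within the scatter), so methoxymethyl may differ from the three earlier groups, but this is not established.

From the compounds shown here alone, how far the true value of compound 4 lies beyond its limit remains open. So does how an amine or a longer chain at this position would read.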